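The source may hold more compounds than are shown below. What is called first, only, known or untested is meant among the compounds shown, and "the series" means these compounds.

Measured compounds in the series:

compound 1, `O=C(O)c1ccc(C(=O)/C(=C\c2ccc(F)c([N+](=O)[O-])c2)SCc2ccc(Cl)cc2)cc1`: 50000 nM
compound 2, `O=C(O)c1ccc(C(=O)/C(=C\c2ccc(F)c([N+](=O)[O-])c2)SCc2ccc(Cl)cc2Cl)cc1`: 1000 nM
compound 3, `Cc1ccc(CS/C(=C/c2ccc(F)c([N+](=O)[O-])c2)C(=O)c2ccc(C(=O)O)cc2)cc1`: 1000 nM

In a functional assay on DU-145 cells (Homo sapiens) for inhibition, read by trypan blue exclusion, with a stated time of 96 h (on this read-out higher numbers stand for weaker inhibition of growth and lower numbers for stronger inhibition of growth), compound 1 gives the highest of the three numbers, with compound 2 and compound 3 both well apart from it. The two measured steps leave compound 1 at the same place of the structure: a 50-fold lower number from compound 1 to compound 2 (1.70 log units; beyond the scatter) and a 50-fold lower number from compound 1 to compound 3 (1.70 log units; beyond the scatter) both concern the aromatic ring on the saturated chain carbon bound to sulfur, and both are large. Compound 2 and compound 3 sit together, as no change at the digits printed from compound 2 to compound 3 (within the scatter) shows.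

Compound 4, `COc1ccc(/C=C(/SCc2ccc(Cl)cc2)C(=O)c2ccc(C(=O)O)cc2)cc1`, has not been measured in this assay. It differs from compound 1 as follows: 4-methoxyphenyl in place of 4-fluoro-3-nitrophenyl on a double-bonded chain carbon bound to a double-bonded chain carbon. Among the measured compounds shown here, this change sits on the double-bonded chain carbon, a place no measured step touches; the steps from compound 1 concern the other ring. They therefore give no direct guide to size or direction here. With compound 1 as the only anchor, at 50000 nM, a step of a 1.7-fold lower number from compound 1 to compound 4 (0.22 log units; within the scatter) is expected, with a wide range around it. The estimate for compound 4 in this assay is 30000 nM, between 5000 nM and 100000 nM.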

Compound 4, concentration for 50% growth inhibition: 10000 nM
Compound 4: the middle estimate sits 3.0-fold (0.48 log units) above what was measured, within the range that was stated.
By their numbers in this assay, from the lowest: compounds 2 and 3 (each within the scatter of the next); then compound 4; then compound 1.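

The ring on the double-bonded chain carbon also bears on growth inhibition in this assay: the 4-fluoro-3-nitrophenyl group is not needed to reach the level of compound 1, since its exchange for 4-methoxyphenyl gives a 5.0-fold lower number from compound 1 to compound 4 (0.70 log units; beyond the scatter). This step is modest, whereas the change on the ring at the saturated chain carbon bound to sulfur gives the large 50-fold lower number from compound 1 to compound 2 (1.70 log units; beyond the scatter), so both ends of the shared core now respond to substitution. The exchange removes the fluorine and the nitro group and introduces the methoxy group in a single step, and nothing available accounts for the shift or assigns it to any one of these groups.

The compounds shown leave open which of these three groups carries the step, and a plain phenyl, a 4-fluorophenyl or a 3-nitrophenyl at this place would separate them. They also leave open whether 4-methoxyphenyl gives a similar step on the core of compound 2 or compound 3, which carry the 2,4-dichlorophenyl and 4-methylphenyl groups on the chain carbon bound to sulfur.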